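Terphenyl benzimidazoles: phenyl replacing dimethoxyphenyl

This account rests on a few compounds, and the source may have more. Where it says the series, first, only, none or still open, it means among the compounds named here.

Measured so far, in a functional assay on KB cells (Homo sapiens) for inhibition, read by sulforhodamine B assay; a lower number here means a stronger inhibitor of growth, a higher number a weaker inhibitor of growth:
compound 1 `COc1ccc(-c2ccc(-c3ccc(-c4nc5cc(C)ccc5[nH]4)cc3)cc2)cc1OC`: 2190 nM
compound 2 `Oc1cccc2[nH]c(-c3ccc(-c4ccc(-c5ccccc5)cc4)cc3)nc12`: 4010 nM
compound 3 `COc1ccc(-c2ccc(-c3ccc(-c4nc5c(O)cccc5[nH]4)cc3)cc2)cc1OC`: 2710 nM

All three values lie within the scatter of one another, so no order among them is read. The change phenyl in place of 3,4-dimethoxyphenyl on an aromatic carbon gave the step of a 1.5-fold higher number from compound 3 to compound 2 (0.17 log units; within the scatter). The cores of compound 1 and compound 3 differ by 5-methyl-1H-benzimidazol-2-yl in place of 4-hydroxy-1H-benzimidazol-2-yl on an aromatic carbon, a change that gave a 1.2-fold higher number from compound 1 to compound 3 (0.09 log units; within the scatter).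

Compound 4 `Cc1ccc2[nH]c(-c3ccc(-c4ccc(-c5ccccc5)cc4)cc3)nc2c1` is not yet measured in this assay. It arises from compound 1 by phenyl in place of 3,4-dimethoxyphenyl on an aromatic carbon. The place of the change is worded the same in both cases, so it is taken as the same change. Among the measured compounds shown here, the step from compound 1 to compound 4 is expected to be a 1.5-fold higher number from compound 1 to compound 4 (0.16 log units; within the scatter), because a 1.5-fold higher number from compound 3 to compound 2 (0.17 log units; within the scatter) is the one measured instance of this change. For compound 4 the estimate in this assay is 3200 nM, expected to fall between 1500 nM and 7000 nM.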

Compound 4, concentration for 50% growth inhibition: 32100 nM
Estimate against measurement, compound 4: 10-fold (1.00 log units) below; the whole stated range lies below it.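

In this assay, phenyl in place of 3,4-dimethoxyphenyl gave a 15-fold higher number from compound 1 to compound 4 (1.17 log units; beyond the scatter), so the size of this step did not carry from one core to the other: the same change on two cores in this assay, a 1.5-fold higher number (0.17 log units; within the scatter) from compound 3 to compound 2 and a 15-fold higher number (1.17 log units; beyond the scatter) from compound 1 to compound 4, 9.9-fold (1.00 log units) apart, beyond the scatter of two such steps. The step therefore cannot be transferred between these cores as a fixed increment. Two pairs do not show why the steps part, nor whether the 5-methyl or the 4-hydroxy group on the benzimidazole decides the outcome.

Open, from the compounds shown here alone, is whether the large step or the small one recurs on further cores. Also open, going by these compounds, is how a single methoxy group, an amine or a carboxylic acid on that aromatic carbon would behave on each core.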